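A Second Trifluoromethyl on the Urea Aryl of Compound 1

The source may report more compounds than this note shows. Statements on the series, on what has been measured and on what is new or still open speak of the compounds shown alone.

Compound 1 `O=C(Nc1cccc(-n2cc(-c3ccncc3)c(-c3ccc(Cl)c(O)c3)n2)c1)Nc1cccc(C(F)(F)F)c1` is the weakest growth inhibitor of the three compounds measured in a functional assay on SK-MEL-28 cells (Homo sapiens) for inhibition, read by sulforhodamine B assay, with a stated time of 48 h; on this read-out higher numbers stand for weaker inhibition of growth and lower numbers for stronger inhibition of growth: compound 1 gives 4110 nM. Compound 2 `O=C(Nc1cccc(-n2cc(-c3ccncc3)c(-c3ccc(Cl)c(O)c3)n2)c1)Nc1ccc(Cl)c(Cl)c1` gives 1460 nM, and compound 3 `COc1cc(-c2nn(-c3cccc(NC(=O)Nc4cccc(C(F)(F)F)c4)c3)cc2-c2ccncc2)ccc1Cl` gives 1120 nM. Both steps away from compound 1 lower the number beyond the scatter: a 2.8-fold lower number from compound 1 to compound 2 (0.45 log units; beyond the scatter), and a 3.7-fold lower number from compound 1 to compound 3 (0.56 log units; beyond the scatter).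

Compound 4 `O=C(Nc1cccc(-n2cc(-c3ccncc3)c(-c3ccc(Cl)c(O)c3)n2)c1)Nc1cc(C(F)(F)F)cc(C(F)(F)F)c1` differs from compound 1 in one place: trifluoromethyl in place of hydrogen on an aromatic carbon. Among the compounds with values here, only the step from compound 1 to compound 2 touches the same aryl on the urea nitrogen, and that exchange of the whole aryl gave a modest lowering; the step to compound 3 alters a different part of the molecule and bears on this change only in showing that compound 1 sits at the weak end of what has been seen. A modest lowering in this assay is therefore expected, though with little certainty. The estimate for compound 4 is 2000 nM, with a range from 700 nM to 6000 nM. As a step this expectation amounts to a 2.1-fold lower number from compound 1 to compound 4 (0.31 log units; beyond the scatter).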

Compound 4, concentration for 50% growth inhibition: 796 nM
For compound 4 the middle estimate is 2.5-fold (0.40 log units) above the measured one, within the range that was stated.
By their numbers in this assay, from the lowest: compounds 4, 3 and 2 (each within the scatter of the next); then compound 1.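

In this assay, adding the second trifluoromethyl gives a 5.2-fold lower number from compound 1 to compound 4 (0.71 log units; beyond the scatter), so this place on the urea aryl, meta to a trifluoromethyl group, accepts a group of 4 heavy atoms with no loss of growth inhibition. The earlier step on this aryl, a 2.8-fold lower number from compound 1 to compound 2 (0.45 log units; beyond the scatter), exchanged the whole aryl and removed the trifluoromethyl; this one shows that a lower number can be reached with the first trifluoromethyl kept and one hydrogen replaced. Nothing shown explains why the number falls.

The compounds shown leave open whether the trifluoromethyl group itself matters at this place, or whether a chlorine, a methyl group, an amine or a carboxylic acid there would serve equally. They also leave open whether this change and the methyl on the oxygen of compound 3 would add up in one molecule.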